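The source may report more compounds than this note shows. Statements on the series, on what has been measured and on what is new or still open speak of the compounds shown alone.

Three compounds that differ only in how they are drawn in space have been measured in a functional assay on A2780 cells (Homo sapiens) for cytotoxicity, read by MTT assay, with a stated time of 24 h; a lower number here means a stronger inhibitor, a higher number a weaker inhibitor. Compound 1 `CCCCC[C@H](C[C@@H](O)C[C@H]1CC=CC(=O)O1)OC` gives 28900 nM, compound 2 `CCCCC[C@@H](C[C@@H](O)C[C@@H]1CC=CC(=O)O1)OC` gives 49400 nM and compound 3 `CCCCC[C@H](C[C@@H](O)C[C@@H]1CC=CC(=O)O1)OC` gives 54500 nM, so compound 3 lies within the scatter of both others. Compound 4 `CCCCC[C@H](C[C@H](O)C[C@H]1CC=CC(=O)O1)OC` keeps the same atoms and bonds as compound 3: the two compounds have the same atoms and bonds and differ only in configuration as drawn: 2 of 3 stereo elements differ; a stereocentre at a saturated chain carbon is drawn R in compound 3 and S in compound 4; a stereocentre at a saturated ring carbon is drawn S in compound 3 and R in compound 4. The measured changes of configuration are the guide, and all are within the scatter: a 1.9-fold higher number from compound 1 to compound 3 (0.28 log units; within the scatter), a 1.1-fold higher number from compound 2 to compound 3 (0.04 log units; within the scatter) and a 1.7-fold higher number from compound 1 to compound 2 (0.23 log units; within the scatter). The chain stereocentre changed here, however, is one that the three measured compounds share, so the range stays broad. No step beyond the scatter is expected in this assay, and the estimate is a 1.3-fold lower number from compound 3 to compound 4 (0.11 log units; within the scatter). For compound 4 the expected value is 42000 nM, with an estimated range of 16000 nM to 95000 nM.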

Compound 4, half-maximal inhibitory concentration: 44000 nM
Estimate against measurement, compound 4: 1.0-fold (0.02 log units) below; the range from low to high includes it.
By their numbers in this assay, from the lowest: compounds 1, 4, 2 and 3 (each within the scatter of the next).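

In this assay, inverting only the chain stereocentre that the other three compounds share gives a 1.5-fold higher number from compound 1 to compound 4 (0.18 log units; within the scatter), so this centre too shows no change beyond the scatter. Inverting all three stereocentres, which gives a mirror-image pair, yields a 1.1-fold lower number from compound 2 to compound 4 (0.05 log units; within the scatter), and the double inversion yields a 1.2-fold lower number from compound 3 to compound 4 (0.09 log units; within the scatter). Among these four compounds, then, no change of configuration produces a step beyond the scatter.

The remaining stereoisomers are open. So is whether an amine in place of the hydroxyl, or a longer chain, would move the number further.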